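The compounds below may be only part of what the source reports. "The series", "measured", "known", "first", "only" and "open" are said of these compounds alone.

In an ADME assay on microsomes from liver (Mus musculus, strain CD-1) for metabolic stability, read by LC-MS, tested at 2 uM (a lower number here means that the compound disappears faster, a higher number that the compound lasts longer), compound 1 (`CNC(=O)c1ccncc1Nc1cc(-c2ccc3ccn(C)c3c2)c2nccnc2c1`) gives 0.45 h and compound 2 (`CN(C)C(=O)c1ccncc1Nc1cc(-c2ccc3ccn(C)c3c2)c2nccnc2c1`) gives 0.35 h. Compound 3 (`Cn1cc(NC(=O)c2ccncc2Nc2cc(-c3ccc4ccn(C)c4c3)c3nccnc3c2)cn1`) gives 0.2 h, a number within the scatter of compound 2 but beyond it, on the low side, from compound 1. Compound 4 (`Cn1cc(CNC(=O)c2ccncc2Nc2cc(-c3ccc4ccn(C)c4c3)c3nccnc3c2)cn1`) awaits measurement. It differs from compound 3 as follows: (1-methyl-1H-pyrazol-4-yl)methyl in place of 1-methyl-1H-pyrazol-4-yl on an amide-type nitrogen. The relevant evidence is the other changes on this amide-type nitrogen. There is a modest 2.3-fold lower number from compound 1 to compound 3 (0.35 log units; beyond the scatter), while a 1.3-fold lower number from compound 1 to compound 2 (0.11 log units; within the scatter) and a 1.8-fold lower number from compound 2 to compound 3 (0.24 log units; within the scatter) both stay within the scatter. None of these steps tests (1-methyl-1H-pyrazol-4-yl)methyl directly, so no change beyond the scatter is expected. The expected step is a 1.3-fold higher number from compound 3 to compound 4 (0.10 log units; within the scatter). For compound 4 the estimate is 0.25 h, with an expected range from 0.12 h to 0.5 h.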

Compound 4, half-life: 0.267 h
Compound 4: middle estimate off by 1.1-fold (0.03 log units), on the low side, and the stated range covers the measured number.
By their numbers in this assay, from the lowest: compounds 3, 4, 2 and 1 (each within the scatter of the next, the first and the last beyond it).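

In this assay, changing 1-methyl-1H-pyrazol-4-yl to (1-methyl-1H-pyrazol-4-yl)methyl on the amide-type nitrogen gives a 1.3-fold higher number from compound 3 to compound 4 (0.13 log units; within the scatter), so this change does not separate the two compounds. The new group also stays within the scatter of the smaller amides, with a 1.3-fold lower number from compound 2 to compound 4 (0.12 log units; within the scatter) and a 1.7-fold lower number from compound 1 to compound 4 (0.23 log units; within the scatter), unlike the directly attached ring, which gave a 2.3-fold lower number from compound 1 to compound 3 (0.35 log units; beyond the scatter). No supporting measurement speaks to why the numbers fall this way. Going by these compounds, whether a longer chain carrying the 1-methyl-1H-pyrazol-4-yl group, an amine or a carboxylic acid on this nitrogen would give a longer half-life stays open.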